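The source may hold more compounds than are shown below. What is called first, only, known or untested is meant among the compounds shown, and "the series" means these compounds.

Compound 1, `C/C=C/C(=O)NCCOc1ccc(Oc2c(-c3ccc(F)cc3)sc3cc(O)ccc23)cc1`, in a functional assay on Ishikawa cells (Homo sapiens) for antiproliferative activity, read by CCK-8 assay, with a stated time of 48 h (on this read-out lower numbers stand for stronger inhibition and higher numbers for weaker inhibition), gives 12400 nM.
Compound 2, `O=C(CCCNCCOc1ccc(Oc2c(-c3ccc(F)cc3)sc3cc(O)ccc23)cc1)N1CCC1`, gives in this assay only the assay limit > 25000 nM, not a number (the limit of > 25000 nM in this assay, at which 1 of the 3 values shown sits).
Compound 3, `C=C(C)C(=O)N1CC(Oc2ccc(Oc3c(-c4ccc(F)cc4)sc4cc(O)ccc34)cc2)C1`, gives 14200 nM.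

Among the two plain numbers, compound 3 holds the higher one, and its nearest neighbour is compound 1 with a 1.1-fold higher number from compound 1 to compound 3 (0.06 log units; within the scatter), so the two are indistinguishable here. Compound 4, `C/C=C/C(=O)N1CC(Oc2ccc(Oc3c(-c4ccc(F)cc4)sc4cc(O)ccc34)cc2)C1`, has not yet been measured. It differs from compound 3 only in the group on the carbonyl of the azetidine: prop-1-en-1-yl in place of 1-methylethenyl on a carbonyl carbon. The same atoms are present, merely joined differently.

Among the compounds with values here, no measured step changes exactly this group alone. The closest comparison is the step of a 1.1-fold higher number from compound 1 to compound 3 (0.06 log units; within the scatter), where compound 1 carries a (prop-1-en-1-yl)carbonyl and compound 3 a (1-methylethenyl)carbonyl, but that step also rebuilds the linker, and it stays within the scatter. The step of an at least 2.0-fold higher number from compound 1 to compound 2 (0.30 log units; that floor lies within the scatter) concerns a much larger rearrangement and offers no guidance on the acyl group. Accordingly, compound 4 is expected to sit near compound 3, with a step of about a 1.0-fold lower number from compound 3 to compound 4 (0.01 log units; within the scatter), nothing beyond the scatter. The estimate for compound 4 is 14000 nM, with a range from 7000 nM to 28000 nM.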

Compound 4, half-maximal inhibitory concentration: 9400 nM
Beside the measured number, compound 4's estimate is 1.5-fold (0.17 log units) above it; measured number inside the range.
By their numbers in this assay, from the lowest: compounds 4, 1 and 3 (each within the scatter of the next). At a limit, above all of these: compound 2.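

In this assay, within the data shown here, the first direct reading of this change, prop-1-en-1-yl in place of 1-methylethenyl on a carbonyl carbon whose other neighbour is an amide-type nitrogen in a ring, gives a 1.5-fold lower number from compound 3 to compound 4 (0.18 log units; within the scatter), so the two arrangements of the same atoms cannot be told apart here; with the (prop-1-en-1-yl)carbonyl now held constant, the linker change alone gives a 1.3-fold lower number from compound 1 to compound 4 (0.12 log units; within the scatter), which also cannot be told apart. Among these compounds, the one step that clears the scatter is an at least 2.6-fold lower number from compound 2 to compound 4 (0.42 log units; beyond the scatter), where 1-((prop-1-en-1-yl)carbonyl)azetidin-3-yl replaces the much longer amino chain on the oxygen. Compound 2 gives only a limit, not a number, so that step is a floor and its true size stays unknown: the limit of > 25000 nM in this assay, at which 1 of the 4 values shown sits.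

The compounds shown leave open whether the double bond of the acyl group matters at all, since a saturated propanoyl group on the same azetidine nitrogen would be needed to test this. They also leave open what a longer chain on the carbonyl, or a dimethylamino group at the end of the prop-1-en-1-yl, would do to the number.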